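The source may hold more compounds than are shown below. What is called first, only, known or untested is meant among the compounds shown, and "the series" means these compounds.

Compound 1 `O=C(NO)c1ccc(CN(Cc2ccncc2)S(=O)(=O)c2cc(F)c(F)c(F)c2F)cc1` and compound 2 `O=C(NO)c1ccc(CN(Cc2cccc(F)c2)S(=O)(=O)c2cc(F)c(F)c(F)c2F)cc1` share the same core and differ only in the group on the saturated chain carbon bound to the sulfonamide nitrogen. In an assay on isolated protein for inhibition of histone deacetylase 11 (Homo sapiens), read by mobility shift assay (a higher number here means a weaker inhibitor, a lower number a stronger inhibitor), compound 1 gives 472 nM. In this assay compound 2 gives 235 nM, the lower of the two numbers shown, although the gap to compound 1 lies within the scatter. The step of a 2.0-fold lower number from compound 1 to compound 2 (0.30 log units; within the scatter) thus shows that swapping pyridin-4-yl for 3-fluorophenyl at this position did not move the number beyond the noise of repeated measurement.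

Compound 3 `O=C(NO)c1ccc(CN(Cc2ccccc2F)S(=O)(=O)c2cc(F)c(F)c(F)c2F)cc1` is the next variation at the same position: 2-fluorophenyl in place of 3-fluorophenyl on a saturated chain carbon bound to a sulfonamide nitrogen. Among the compounds with values here, the only measured step that touches this position is the one within the scatter just described, and the change here is smaller still, since the same atoms are simply joined differently. No step beyond the scatter is therefore expected. The estimated step is a 1.1-fold higher number from compound 2 to compound 3 (0.04 log units; within the scatter), within the scatter. Compound 3 is expected to give about 260 nM in this assay, with a range from 110 nM to 650 nM.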

Compound 3, half-maximal inhibitory concentration: 263 nM
The estimate for compound 3 lay 1.0-fold (0.00 log units) below the measured number; the measured number falls inside the stated range.
By their numbers in this assay, from the lowest: compounds 2, 3 and 1 (each within the scatter of the next).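

Placing the fluorine differently on the ring, 2-fluorophenyl in place of 3-fluorophenyl, gives (a 1.1-fold higher number from compound 2 to compound 3 (0.05 log units; within the scatter)) in this assay, so this pair adds something the first comparison could not show: at this position, two groups made of exactly the same atoms and differing only in how they are joined cannot be told apart in this assay. The comparison with the pyridine-bearing compound gives (a 1.8-fold lower number from compound 1 to compound 3 (0.25 log units; within the scatter)), so a second fluorophenyl group also stays within the scatter of pyridin-4-yl, and all three groups on the saturated chain carbon bound to the sulfonamide nitrogen now read alike within the limits of repeated measurement. No measured information on these compounds bears on what lies behind this result.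

All three groups shown are single six-membered aromatic rings, so it remains open whether this position would respond at all to something quite different, such as a cyclohexyl ring, a carboxylic acid, an amine or a longer chain. As far as these compounds go, it also remains open whether 4-fluorophenyl, the remaining placement of the fluorine on this ring, would read like its two relatives.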